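Shorter Carbamoyl Arm in Place of Acetamidopentyl Chain

The source may report more compounds than this note shows. Statements on the series, on what has been measured and on what is new or still open speak of the compounds shown alone.

Compound 3 `CCCC(=O)OCSc1ccccc1C(=O)NCCCCCCNC(C)=O` holds the lowest of the two numbers in an ADME assay on CEM-SS cells (Homo sapiens) for cytotoxicity, read by XTT assay, with a stated time of 6 days; a higher number here means that more compound is tolerated, a lower number that less compound is tolerated; compound 3 gives 8 uM. Compound 2 `CCCC(=O)OCSc1ccccc1C(=O)NCCCCNC(C)=O` gives 17.4 uM. Compound 1 `CCCC(=O)OCSc1ccc(OC)cc1C(=O)NCCC(N)=O` reaches only > 100 uM, which is a limit of the assay rather than a number, as noted in the limit of > 100 uM in this assay, at which 1 of the 3 values shown sits. Among the compounds with values here, the one measured step, a 2.2-fold lower number from compound 2 to compound 3 (0.34 log units; beyond the scatter), ran from a shorter chain to a longer one and lowered the tolerated concentration modestly. Compound 4 `CCCC(=O)OCSc1ccccc1C(=O)NCC(=O)NCCN(C)C` carries the change ((2-(dimethylamino)ethyl)carbamoyl in place of 5-acetamidopentyl on a saturated chain carbon bound to an amide-type nitrogen). Within the data shown here, that step argues, in reverse, for a somewhat higher number; the dimethylamino part has no counterpart among the measured compounds, so the expected step, a 2.3-fold higher number from compound 3 to compound 4 (0.35 log units; beyond the scatter), is kept small. Compound 4 is estimated at 18 uM, within a range from 6 uM to 60 uM.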

Compound 4, half-maximal toxic concentration: 76.9 uM
Compound 4: the middle estimate sits 4.3-fold (0.63 log units) below what was measured; the whole stated range lies below it.
By their numbers in this assay, from the lowest: compound 3; then compound 2; then compound 4. At a limit, above all of these: compound 1.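

At this position, on a saturated chain carbon bound to an amide-type nitrogen, the (2-(dimethylamino)ethyl)carbamoyl group gives a 9.6-fold higher number from compound 3 to compound 4 (0.98 log units; beyond the scatter) and, in place of 3-acetamidopropyl, a 4.4-fold higher number from compound 2 to compound 4 (0.65 log units; beyond the scatter). Within the data shown here, the tolerated concentration here is therefore not tied to the acetamido-ended chains, the only kind the earlier comparison covered. Compound 1 alone stands at a limit in this assay: the limit of > 100 uM in this assay, at which 1 of the 4 values shown sits.

On these data alone, compound 4 changes the carbamoyl link and the dimethylamino end at once, and what each contributes stays open. A carboxylic acid at the chain end, or a longer chain before the dimethylamino group, remains untested among the compounds shown.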